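The source may report more compounds than this note shows. Statements on the series, on what has been measured and on what is new or still open speak of the compounds shown alone.

Measured compounds in an ADME assay on BHK cells (Mesocricetus auratus) for cytotoxicity; a higher number here means that more compound is tolerated, a lower number that less compound is tolerated:
compound 1 `CCNC1=NC(=O)[C@H]([C@H](C)c2c[nH]c3ccccc23)S1` — 10 ug/mL
compound 2 `C[C@H](c1c[nH]c2ccccc12)[C@@H]1SC(N)=NC1=O` — 100 ug/mL
compound 3 `CNC1=NC(=O)[C@H]([C@H](C)c2c[nH]c3ccccc23)S1` — 10 ug/mL

Compound 3 stands level with compound 1 at the digits given, the two together the lowest numbers of the three; compound 2 sits at the top, the step of a 10-fold lower number from compound 2 to compound 3 (1.00 log units; beyond the scatter) separating it from compound 3, while the step of no change at the digits printed from compound 1 to compound 3 (within the scatter) lies within the scatter.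

Compound 4 `C[C@H](c1c[nH]c2ccccc12)[C@@H]1SC(NCCO)=NC1=O` is not yet measured. It differs from compound 3 in one place: hydroxymethyl in place of hydrogen on a saturated chain carbon bound to an amine nitrogen. Among the measured compounds shown here, two measured steps bear on the substituent of this amine nitrogen: no change at the digits printed from compound 1 to compound 3 (within the scatter), where a shorter chain on the nitrogen left the number unmoved, and a 10-fold higher number from compound 1 to compound 2 (1.00 log units; beyond the scatter), where hydrogen in place of ethyl on the amine nitrogen raised it. For the measured compounds named here, compound 4 keeps a chain on the nitrogen and changes methyl to 2-hydroxyethyl; no measured compound carries a hydroxyl on that chain, so the only direct guide is the unchanged step from ethyl to methyl. The expected step in this assay is therefore a 1.2-fold higher number from compound 3 to compound 4 (0.08 log units; within the scatter), none beyond the scatter, with a slight lean toward a higher number. Compound 4 is expected to give 12 ug/mL, with a range of 5 ug/mL to 40 ug/mL.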

Compound 4, minimum cytotoxic concentration: 100 ug/mL
Compound 4: the middle estimate sits 8.3-fold (0.92 log units) below what was measured, and the stated range ends below it.
By their numbers in this assay, from the lowest: compounds 1 and 3 (each within the scatter of the next); then compounds 2 and 4 (each within the scatter of the next).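

Working notes on the amine nitrogen substituent in this assay: a chain on this nitrogen does not by itself go with the lower number, since the hydroxy group on the ethyl chain gives a 10-fold higher number from compound 1 to compound 4 (1.00 log units; beyond the scatter), and the change from methyl to 2-hydroxyethyl gives a 10-fold higher number from compound 3 to compound 4 (1.00 log units; beyond the scatter). Set against the unsubstituted amine, the 2-hydroxyethyl chain gives no change at the digits printed from compound 2 to compound 4 (within the scatter), so a substituent at this position can stand level with hydrogen, which neither methyl nor ethyl did in the earlier compounds. Nothing available here accounts for this difference between the hydroxylated chain and the plain alkyl chains, and the finding rests on the numbers alone.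

The compounds shown do not separate a role for the hydroxy group itself from that of any other group on the chain, so a methoxy group, a primary amine or a carboxylic acid in its place remains an open comparison. Also open, on these data alone, is whether a longer chain such as 3-hydroxypropyl, or a hydroxyl on a branched chain, would stay level with compound 2 in this assay.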